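Carbamoyl Replaces Oxadiazole in a Purinoceptor Binder

The source may report more compounds than this note shows. Statements on the series, on what has been measured and on what is new or still open speak of the compounds shown alone.

Of the compounds shown here, two on a shared core have been measured in an assay on HEK293 cells for displacement of a labelled ligand from P2Y purinoceptor 1 (Homo sapiens), read by scintillation counting, with a stated time of 1 h; a lower number here means a stronger inhibitor, a higher number a weaker inhibitor. Compound 1 `Cc1sc(Nc2cccnc2Oc2ccccc2C(C)(C)C)nc1C(F)(F)F` carries a methyl group on an aromatic carbon of its five-membered ring, and in this assay compound 1 gives 11 nM. Compound 2 `Cc1noc(-c2sc(Nc3cccnc3Oc3ccccc3C(C)(C)C)nc2C(F)(F)F)n1` carries a 3-methyl-1,2,4-oxadiazol-5-yl group at that same carbon, and in this assay compound 2 gives 6 nM. That exchange produced a 1.8-fold lower number from compound 1 to compound 2 (0.26 log units; within the scatter), so the two numbers cannot be separated, and compound 2 stands at one end of a pair whose members are indistinguishable within the usual scatter.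

Compound 3 `CC(C)(C)c1ccccc1Oc1ncccc1Nc1nc(C(F)(F)F)c(C(N)=O)s1` is not yet measured. Its difference from compound 2 is carbamoyl in place of 3-methyl-1,2,4-oxadiazol-5-yl on an aromatic carbon. For the measured compounds named here, only one measured step touches this position, a 1.8-fold lower number from compound 1 to compound 2 (0.26 log units; within the scatter), and it shows that a methyl and an oxadiazole there give numbers within the scatter of each other. Carbamoyl is a third, smaller group not yet tried, so a step beyond the scatter in this assay is not expected in either direction, and the estimate leans toward no change. The expected value for compound 3 in this assay is 10 nM, with a range from 3 nM to 40 nM, which means an expected step of a 1.7-fold higher number from compound 2 to compound 3 (0.22 log units; within the scatter).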

Compound 3, inhibition constant: 4850 nM
Compound 3: the middle estimate sits 490-fold (2.69 log units) below what was measured; the measured number lies above the stated range.
By their numbers in this assay, from the lowest: compounds 2 and 1 (each within the scatter of the next); then compound 3.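

This carbon of the shared core is far less forgiving than the methyl and 3-methyl-1,2,4-oxadiazol-5-yl pair suggested: in this assay, carbamoyl gives an 810-fold higher number from compound 2 to compound 3 (2.91 log units; beyond the scatter) and a 440-fold higher number from compound 1 to compound 3 (2.64 log units; beyond the scatter), both large steps well beyond the scatter. Size alone does not order these results, since carbamoyl has fewer heavy atoms than the 3-methyl-1,2,4-oxadiazol-5-yl group and more than methyl, yet its number stands far above both. Of the three groups, only carbamoyl carries a hydrogen-bond donor, but nothing available shows whether that feature is connected with the higher number.

The compounds shown leave open whether this jump belongs to the carbamoyl group as a whole or specifically to the amide hydrogens. A nitrile, a methyl ester or an N,N-dimethylcarbamoyl group at this carbon would help separate those possibilities, and a carboxylic acid or an aminomethyl group would show how other groups fare at this position.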